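The compounds below may be only part of what the source reports. "The series", "measured", "known", "first", "only" and "open" are said of these compounds alone.

Compound 1 `CCCC(=O)OCSc1ccccc1C(=O)NCCCNC(C)=O` and compound 2 `CCCC(=O)OCSc1ccccc1C(N)=O` share a core and differ in one place. In an ADME assay on CEM-SS cells (Homo sapiens) for cytotoxicity, read by XTT assay, with a stated time of 6 days (on this read-out higher numbers stand for lower toxicity in this test and lower numbers for higher toxicity in this test), compound 1 gives 21.1 uM, and compound 2 gives 12.4 uM; the two numbers lie close together, as the step of a 1.7-fold lower number from compound 1 to compound 2 (0.23 log units; within the scatter) shows, so neither stands apart from the other. Compound 3 `CCCCCNC(=O)CNC(=O)c1ccccc1SCOC(=O)CCC` has not been measured. It differs from compound 1 by pentylcarbamoyl in place of 2-acetamidoethyl on a saturated chain carbon bound to an amide-type nitrogen. Among the measured compounds shown here, the only measured step that bears on this, from compound 1 to compound 2, swapped the whole side chain on the amide-type nitrogen for hydrogen and stayed within the scatter, which gives little reason to expect a large change here. Compound 3 is therefore expected to give about 18 uM in this assay, within a range from 8 uM to 40 uM. That estimate means a step of a 1.2-fold lower number from compound 1 to compound 3 (0.07 log units; within the scatter), expected to stay within the scatter.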

Compound 3, half-maximal toxic concentration: 24.8 uM
Estimate against measurement, compound 3: 1.4-fold (0.14 log units) below, within the range that was stated.
By their numbers in this assay, from the lowest: compounds 2, 1 and 3 (each within the scatter of the next).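

In this assay, putting pentylcarbamoyl in place of 2-acetamidoethyl on a saturated chain carbon bound to an amide-type nitrogen gives a 1.2-fold higher number from compound 1 to compound 3 (0.07 log units; within the scatter), so this exchange of one side chain for another leaves no change that can be told from the scatter. The earlier pair showed this only for replacing the whole side chain on the amide-type nitrogen with hydrogen; here a group of 8 heavy atoms replaces one of 6, and neither group has a ring. No measurement is available that bears on why these numbers stay so close.

The compounds shown leave open whether a side chain ending in an amine or a carboxylic acid would also stay within the scatter. They also leave open whether a phenyl ring on this chain would do the same.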